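A few compounds are considered here, and "the series" means these few. Any claim that something is new, unique, unknown or untested is made for them only; others in the source may bear on it.

Compound 3, `NC1=NC2(CCOCC2)N(OCCCOc2cccc(Cl)c2Cl)C(N)=N1`, carries a 2,3-dichlorophenyl on an oxygen on a saturated carbon. In a functional assay on HL-60 cells (Homo sapiens) for antiproliferative activity, read by MTT assay, with a stated time of 72 h (a lower number here means a stronger inhibitor, a higher number a weaker inhibitor), compound 3 gives 440 nM, the lowest of the three numbers recorded so far. Compound 1, `NC1=NC2(CCOCC2)N(OCCCOc2ccc(Cl)c(Cl)c2)C(N)=N1`, gives 1240 nM in this assay, and compound 2, `NC1=NC2(CCOCC2)N(OCCCOc2cc(Cl)c(Cl)cc2Cl)C(N)=N1`, gives 2360 nM. The step of a 2.8-fold lower number from compound 1 to compound 3 (0.45 log units; beyond the scatter) and the step of a 5.4-fold lower number from compound 2 to compound 3 (0.73 log units; beyond the scatter) both show that changing the chlorine pattern on the phenyl shifts the number by a modest amount, whereas a 1.9-fold higher number from compound 1 to compound 2 (0.28 log units; within the scatter), which adds a chlorine, stays within the scatter.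

Compound 4, `NC1=NC2(CCOCC2)N(OCCCOc2ccccc2Br)C(N)=N1`, differs from compound 3 in one place: 2-bromophenyl in place of 2,3-dichlorophenyl on an oxygen on a saturated carbon. Among the measured compounds shown here, no measured step swaps chlorine for bromine or removes a halogen from this ring, so the closest guides are the two steps that altered the aryl pattern, both modest in size. Since those steps ran toward compound 3 from each of the other two patterns, a move away from 2,3-dichlorophenyl is expected to give a modestly higher number, a 1.8-fold higher number from compound 3 to compound 4 (0.26 log units; within the scatter), though a step within the scatter cannot be excluded. Compound 4 is therefore estimated at 800 nM in this assay, with a range from 300 nM to 2000 nM.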

Compound 4, half-maximal inhibitory concentration: 610 nM
The estimate for compound 4 lay 1.3-fold (0.12 log units) above the measured number, within the range that was stated.
By their numbers in this assay, from the lowest: compounds 3 and 4 (each within the scatter of the next); then compounds 1 and 2 (each within the scatter of the next).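

In this assay, the step of a 1.4-fold higher number from compound 3 to compound 4 (0.14 log units; within the scatter) shows that 2-bromophenyl and 2,3-dichlorophenyl cannot be told apart at this position, on an oxygen on a saturated carbon, so the low number is no longer tied to 2,3-dichlorophenyl alone. The 2-bromophenyl also stands clear of the other two aryl patterns, with a 2.0-fold lower number from compound 1 to compound 4 (0.31 log units; beyond the scatter) against 3,4-dichlorophenyl and a 3.9-fold lower number from compound 2 to compound 4 (0.59 log units; beyond the scatter) against 2,4,5-trichlorophenyl, both modest steps, so the four compounds fall into two groups rather than following the number of halogens on the ring alone. Nothing available gives a reason for these differences.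

The compounds shown leave open whether a bromine is needed at all, since a plain phenyl, a 2-chlorophenyl or a 2-fluorophenyl would separate the effect of the halogen's identity from that of the rest of the substitution pattern. They also leave open how a 2-methoxyphenyl, a 2-aminophenyl or a longer chain between the oxygen atoms would fare on the same core.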